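The source may report more compounds than this note shows. Statements on the series, on what has been measured and on what is new or still open speak of the compounds shown alone.

Measured in a functional assay, read by Griess assay, with a stated time of 2.5 h (a lower number here means a stronger inhibitor, a higher number a weaker inhibitor), so far
Compound 1 (`COc1cc(OC)c(OC)cc1/C=C/C(=O)c1ccc(Cl)cc1`) reads 2.01 ug/mL
Compound 2 (`COc1cc(OC)c(OC)cc1/C=C/C(=O)c1ccc(C)cc1`) reads 2.18 ug/mL
Compound 3 (`COc1cc(OC)c(OC)cc1/C=C/C(=O)c1ccc(F)cc1`) reads 1.96 ug/mL

Compound 3 gives 1.96 ug/mL and stands level with the other two compounds, so no ranking can be drawn among the three. The measured steps are a 1.1-fold higher number from compound 1 to compound 2 (0.04 log units; within the scatter) and a 1.0-fold lower number from compound 1 to compound 3 (0.01 log units; within the scatter) together with a 1.1-fold lower number from compound 2 to compound 3 (0.05 log units; within the scatter) and each one is small enough to vanish into the ordinary variation between repeats.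

Compound 4 (`COc1cc(OC)c(OC)cc1/C=C/C(=O)c1cc(O)ccc1O`) is the next case, with 2,5-dihydroxyphenyl in place of 4-fluorophenyl on a carbonyl carbon as its change from compound 3: 2,5-dihydroxyphenyl in place of 4-fluorophenyl on a carbonyl carbon. The three measured steps bear on this only loosely. Among the measured compounds shown here, they show that swapping chloro, methyl and fluoro made no visible difference, but no measured compound carries a hydroxy group, and the data give no firm direction for this larger swap.

The estimated change is a 1.2-fold lower number from compound 3 to compound 4 (0.09 log units; within the scatter) which means no expected step beyond the scatter, though with real uncertainty. For compound 4 the estimated value is 1.6 ug/mL with an expected range from 0.5 ug/mL to 5 ug/mL in this assay for now.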

Compound 4, half-maximal inhibitory concentration: 2.44 ug/mL
Estimate against measurement, compound 4: 1.5-fold (0.18 log units) below; low and high end bracket the measured number.
By their numbers in this assay, from the lowest: compounds 3, 1, 2 and 4 (each within the scatter of the next).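

Replacing the whole aromatic group on the carbonyl carbon, rather than a single substituent on it, gives a 1.2-fold higher number from compound 3 to compound 4 (0.10 log units; within the scatter) and a 1.1-fold higher number from compound 2 to compound 4 (0.05 log units; within the scatter) as well as a 1.2-fold higher number from compound 1 to compound 4 (0.08 log units; within the scatter) in this assay and so leaves every comparison within the scatter. This extends the earlier picture: 2,5-dihydroxyphenyl brings hydrogen-bond donors and acceptors that the other three groups lack, yet the reading does not separate from theirs. No measurement here offers an explanation for this result.

As far as these compounds go, all four compounds carry a six-membered aromatic ring of carbon only at this place, so it remains open how a carboxylic acid or amine on that ring, or a saturated cyclohexyl group in its place, would read. Also open, from the compounds shown here alone, is what a single hydroxy group would do on its own.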